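Thiophene sulfonamide ureas against HeLa cells: a weak series

The source may report more compounds than this note shows. Statements on the series, on what has been measured and on what is new or still open speak of the compounds shown alone.

Measured so far:
compound 1 `O=C(NCCNS(=O)(=O)c1ccc(-c2ccccc2O[C@H]2CC[C@H](O)CC2)s1)Nc1cc(Cl)cc(Cl)c1`: > 20000 nM
compound 2 `O=[N+]([O-])c1cccc(NC(=S)NCCNS(=O)(=O)c2ccc(-c3ccccc3OCc3ccccc3)s2)c1`: 12800 nM
compound 3 `O=C(NCCNS(=O)(=O)c1ccc(-c2ccccc2O[C@H]2CC[C@H](O)CC2)s1)Nc1ccc([N+](=O)[O-])cc1`: 10500 nM

In a functional assay on HeLa cells (Homo sapiens) for inhibition, read by CCK-8 assay, with a stated time of 48 h (on this read-out lower numbers stand for stronger inhibition and higher numbers for weaker inhibition), compound 1 reaches only the limit of the method, > 20000 nM, which the limit of > 20000 nM in this assay, at which 1 of the 3 values shown sits, records as such. Of the two proper numbers, that of compound 2 is the higher, yet compound 3 sits within the usual scatter of it, so the two cannot be told apart. Among the measured compounds shown here, the one step between compounds differing in a single place is an at least 1.9-fold lower number from compound 1 to compound 3 (0.27 log units; that floor lies within the scatter); its floor lies within the scatter, so it shows no change that can be trusted.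

Compound 4 `COc1ccc(NC(=O)NCCNS(=O)(=O)c2ccc(-c3ccccc3OCc3ccccc3)s2)cc1` is not yet measured. It differs from compound 2 by a group of 11 heavy atoms (8 carbon, 1 nitrogen, 2 oxygen; one six-membered aromatic ring of carbon only) in place of a group of 12 heavy atoms (7 carbon, 2 nitrogen, 2 oxygen, 1 sulfur; one six-membered aromatic ring of carbon only), on an amine nitrogen. The step from compound 1 to compound 3 likewise swaps the aryl group on the amide-type nitrogen and gave nothing beyond the scatter, so no step beyond the scatter is expected here in this assay either; the change from thiourea to urea has no single-place comparison among the measured compounds. Compound 4 is therefore expected to give 15000 nM, between 5000 nM and 40000 nM, which is an estimated step of a 1.2-fold higher number from compound 2 to compound 4 (0.07 log units; within the scatter).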

Compound 4, half-maximal inhibitory concentration: > 50000 nM
Compound 4: no number, only a limit; the forecaster's own chance of this, stated with the estimate: 35%; middle value at least 3.3-fold (0.52 log units) from the limit.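

In this assay, putting (4-methoxyphenyl)carbamoyl on the amine nitrogen in place of the sulfur-bearing group gives an at least 3.9-fold higher number from compound 2 to compound 4 (0.59 log units; beyond the scatter), so what this nitrogen carries can move the read-out, which the earlier step on an amide-type nitrogen, with its floor within the scatter, could not show. From the compounds shown here alone, the move is towards weaker inhibition, but its full size is unknown, as compound 4 gives a limit and not a number: the limit of > 50000 nM in this assay, at which 1 of the 4 values shown sits. This rests on a single pair of compounds and sets no pattern for the series.

The exchange alters the linking unit and the aromatic ring substituent together, so the compounds shown leave open which of the two carries the step. Also open, going by these compounds, is how this assay would read with a carboxylic acid or an amine on that aromatic ring, or with a longer chain on the amine nitrogen.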